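Hydroxy at the diphenyl carbon of compound 2

This account rests on a few compounds, and the source may have more. Where it says the series, first, only, none or still open, it means among the compounds named here.

Compound 1 `Cc1nc2cnccc2n1CC1CCN(C(=O)CC(C)c2ccccc2)CC1` gives 0.033 mg/kg in a functional assay on the whole organism (arterial blood) with Rattus norvegicus as the target; on this read-out higher numbers stand for an effect only at larger amounts of compound and lower numbers for an effect already at smaller amounts. Going by the values given here, compound 2 `Cc1nc2cnccc2n1CC1CCN(C(=O)CC(c2ccccc2)c2ccccc2)CC1` gives 0.0086 mg/kg in this assay, the lowest of the two numbers so far, reached by a 3.8-fold lower number from compound 1 to compound 2 (0.58 log units; beyond the scatter). Compound 3 `Cc1nc2cnccc2n1CC1CCN(C(=O)CC(O)(c2ccccc2)c2ccccc2)CC1` carries hydroxy in place of hydrogen on a saturated chain carbon bound to two aromatic carbons and a saturated chain carbon. Among the compounds with values here, no measured step covers a hydroxy entering at this carbon; the single known step, phenyl in place of methyl, does not speak to it directly. For compound 3 a step of modest size in either direction, or none beyond the scatter, is expected, estimated as a 1.4-fold higher number from compound 2 to compound 3 (0.14 log units; within the scatter). Compound 3 is expected at 0.012 mg/kg, within 0.004 mg/kg to 0.04 mg/kg.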

Compound 3, dose for 50% inhibition: 0.013 mg/kg
The estimate for compound 3 lay 1.1-fold (0.03 log units) below the measured number; low and high end bracket the measured number.
By their numbers in this assay, from the lowest: compounds 2 and 3 (each within the scatter of the next); then compound 1.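

In this assay, hydroxy in place of hydrogen on a saturated chain carbon bound to two aromatic carbons and a saturated chain carbon gives a 1.5-fold higher number from compound 2 to compound 3 (0.18 log units; within the scatter) and stays within the scatter. Compound 1 and compound 2 showed only a phenyl-for-methyl change at this carbon; compound 3 shows that a hydroxy, with its hydrogen-bond donor and acceptor, is accepted here without a change beyond the scatter. Nothing available gives a reason for this result.

Open, going by these compounds, is whether a methoxy, an amine or a fluorine at this carbon would also stay within the scatter of compound 2. Also open, on these data alone, is whether hydroxy would be accepted as well on the methyl-bearing carbon of compound 1.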